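A few compounds are considered here, and "the series" means these few. Any claim that something is new, unique, unknown or untested is made for them only; others in the source may bear on it.

Measured so far in a functional assay on HCT-116 cells (Homo sapiens), read by MTT assay, with a stated time of 72 h; on this read-out higher numbers stand for weaker inhibition and lower numbers for stronger inhibition:

Compound 1, `C#Cc1cn([C@@H]2O[C@H](CO)[C@@H](O)[C@H]2O)c2ncnc(C)c12` — > 20000 nM in this assay, a limit of the assay, not a number.
Compound 2, `C#Cc1cn([C@@H]2O[C@H](CO)[C@@H](O)[C@H]2O)c2ncnc(NC)c12` — > 20000 nM in this assay, likewise a limit.
Compound 3, `C#Cc1cn([C@@H]2O[C@H](CO)[C@@H](O)[C@H]2O)c2ncnc(OC)c12` — 5140 nM in this assay.

Compound 2 sits at the limit of > 20000 nM in this assay, at which 2 of the 3 values shown sit, so only a limit is known for it. The steps measured so far all concern the other aromatic carbon of the shared core: a step that the two limits leave unreadable from compound 1 to compound 2 is left unreadable by the two limits, while an at least 3.8-fold lower number from compound 1 to compound 3 (0.59 log units; beyond the scatter) and an at least 3.8-fold lower number from compound 2 to compound 3 (0.59 log units; beyond the scatter) both reach a readable, at least modest size. None of them touches the place changed here.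

Compound 4, `CNc1ncnc2c1c(-c1ccco1)cn2[C@@H]1O[C@H](CO)[C@@H](O)[C@H]1O`, differs from compound 2 by furan-2-yl in place of ethynyl on an aromatic carbon. Among the compounds with values here, no measured step in this assay bears on this change, so no direction can be read from the series for it. The limit of compound 2 leaves the starting point itself open, and an estimate for compound 4 can only rest on the weak showing of the whole series.

Compound 4 is therefore expected to remain weak in this assay, at 12000 nM with a range of 2000 nM to 50000 nM; the expected step of an at least 1.6-fold lower number from compound 2 to compound 4 (0.22 log units; that floor lies within the scatter) is a guess only, and a further limit is about as likely as a number.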

Compound 4, half-maximal inhibitory concentration: 440 nM
Beside the measured number, compound 4's estimate is 27-fold (1.44 log units) above it; the whole stated range lies above it.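

In this assay, within the data shown here, the step of an at least 45-fold lower number from compound 2 to compound 4 (1.65 log units; beyond the scatter) is the first reading at the aromatic carbon two ring bonds from the ring nitrogen, and it shows that this place can move the read-out strongly. All earlier readable steps concerned the other aromatic carbon of the shared core, so none showed that exchanging ethynyl for furan-2-yl could bring a compound with the methylamino group down to a measurable number. Going by these compounds, this step is only a floor, and its full size remains unknown, as compound 2 stands at a limit of the assay: the limit of > 20000 nM in this assay, at which 2 of the 4 values shown sit.

On these data alone, whether the effect needs furan-2-yl itself remains open, since a phenyl or thiophen-2-yl ring at this place would be needed to test it. As far as these compounds go, how furan-2-yl combines with methoxy on the other aromatic carbon also remains open.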